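The source may hold more compounds than are shown below. What is called first, only, known or untested is meant among the compounds shown, and "the series" means these compounds.

Working notes on the series. Compound 1 `COc1cccc(OC)c1C(=O)Nc1nnc(-c2ccc(Cl)cc2)s1` gives 58.9 nM in a functional assay on the whole organism (integument) for inhibition, with Chilo suppressalis as the target, read by scintillation counting, with a stated time of 72 h; on this read-out higher numbers stand for weaker inhibition and lower numbers for stronger inhibition. Compound 2 `O=C(Nc1nnc(-c2ccc(Cl)cc2)s1)c1ccccc1I` returns only a limit in this assay, > 5010 nM, which is the limit of > 5010 nM in this assay, at which 1 of the 3 values shown sits. Compound 3 `COc1cccc(OC)c1C(=O)Nc1nnc(-c2ccc(C)cc2)s1` gives 1230 nM in this assay and stands highest of the two numbers shown; the single measured step that reaches it, a 21-fold higher number from compound 1 to compound 3 (1.32 log units; beyond the scatter), is large. Compound 4 `COc1cccc(OC)c1C(=O)Nc1nnc(-c2ccc(C(C)(C)C)cc2)s1` has not yet been measured; it differs from compound 3 by tert-butyl in place of methyl on an aromatic carbon. Going by the values given here, no measured step exchanges one alkyl group for another at this carbon, so the only step on the same carbon, a 21-fold higher number from compound 1 to compound 3 (1.32 log units; beyond the scatter), bears on it indirectly: it concerns chloro against methyl, not methyl against tert-butyl, and shows that this position moves the read-out strongly. Compound 3 already sits at the high end of the numbers shown, and the move in this assay for compound 4 is expected to be modest and, if anything, upward, with wide uncertainty; the estimated step is a 2.0-fold higher number from compound 3 to compound 4 (0.31 log units; beyond the scatter). Compound 4 is therefore estimated at 2500 nM, within 600 nM to 10000 nM, with a real chance that only a limit is returned.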

Compound 4, half-maximal inhibitory concentration: 912 nM
For compound 4 the middle estimate is 2.7-fold (0.44 log units) above the measured one, within the range that was stated.
By their numbers in this assay, from the lowest: compound 1; then compounds 4 and 3 (each within the scatter of the next). At a limit, above all of these: compound 2.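

In this assay, tert-butyl in place of methyl gives a 1.3-fold lower number from compound 3 to compound 4 (0.13 log units; within the scatter), so on this carbon the two alkyl groups are not told apart despite their difference in size. Chloro stands apart from both: alongside the earlier methyl step, tert-butyl in place of chloro gives a 15-fold higher number from compound 1 to compound 4 (1.19 log units; beyond the scatter), showing that the large rise seen with compound 3 is not peculiar to methyl. Nothing given here accounts for either step.

Going by these compounds, whether fluoro, bromo, methoxy or an amine on this carbon would read with chloro or with the alkyl groups remains open. Also open, on these data alone, is whether a carboxylic acid here would fall outside both sets of values.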